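Replacing a methyl by 4-hydroxyphenyl on a thiophene ketone

The source may report more compounds than this note shows. Statements on the series, on what has been measured and on what is new or still open speak of the compounds shown alone.

Compound 2 `Cc1ccc(C(=O)c2sc(NC(C)C)c(C#N)c2N)s1` is the weaker of the two compounds measured in an assay for inhibition of Maternal embryonic leucine zipper kinase (Homo sapiens), read by ADP-Glo, with a stated time of 0.5 h; a lower number here means a stronger inhibitor, a higher number a weaker inhibitor: compound 2 gives 494 nM, while compound 1 `CC(C)Nc1sc(C(=O)c2ccc(Br)s2)c(N)c1C#N` gives 122 nM. Going by the values given here, the single measured step, a 4.0-fold higher number from compound 1 to compound 2 (0.61 log units; beyond the scatter), shows that a change at this position, next to the ring sulfur, moves the number by a modest amount. Compound 3 `CC(C)Nc1sc(C(=O)c2ccc(-c3ccc(O)cc3)s2)c(N)c1C#N` has not yet been measured; it differs from compound 2 by 4-hydroxyphenyl in place of methyl on an aromatic carbon. Among the compounds with values here, only the step from compound 1 to compound 2 bears on this change, and it concerns a different replacement at the same carbon, so the direction for a larger aromatic group is uncertain. Because compound 1 with bromo gives 122 nM and compound 2 with methyl gives 494 nM, a change of up to a modest size in either direction is expected, with a somewhat lower number slightly favoured. Compound 3 is therefore estimated at 280 nM in this assay, within 70 nM to 1100 nM, a step of a 1.8-fold lower number from compound 2 to compound 3 (0.25 log units; within the scatter).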

Compound 3, half-maximal inhibitory concentration: 241 nM
Compound 3: middle estimate off by 1.2-fold (0.07 log units), on the high side; low and high end bracket the measured number.
By their numbers in this assay, from the lowest: compounds 1 and 3 (each within the scatter of the next); then compound 2.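

In this assay, the carbon next to the ring sulfur takes a much larger group than methyl without any loss: a 2.0-fold lower number from compound 2 to compound 3 (0.31 log units; beyond the scatter), so the 4-hydroxyphenyl, with its six-membered aromatic ring, is tolerated here. Against bromo the picture is different, since a 2.0-fold higher number from compound 1 to compound 3 (0.30 log units; within the scatter) and the two compounds cannot be told apart, which leaves compound 2 with methyl as the only one of the three that stands apart from the others. Nothing available here explains why these groups give these numbers.

Going by these compounds, what a plain phenyl or a 4-methoxyphenyl would give on this carbon remains open, so the share of the hydroxyl cannot be separated from that of the ring itself. Whether a 4-aminophenyl or a longer chain would fare differently is also unsettled.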